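A cyanophenyl swap among three closely matched compounds

The compounds below may be only part of what the source reports. "The series", "measured", "known", "first", "only" and "open" are said of these compounds alone.

Compound 1 `COc1cc(/C=C2\CN(C)C/C(=C\c3ccc(C#N)cc3)C2=O)cc(OC)c1`: 14000 nM
Compound 2 `COc1cc(/C=C2\CN(C)C/C(=C\c3ccc(Cl)cc3)C2=O)cc(OC)c1OC`: 14000 nM
Compound 3 `COc1cc(/C=C2\CN(C)C/C(=C\c3ccc(Cl)cc3Cl)C2=O)cc(OC)c1OC`: 13400 nM

All three values come from an ADME assay on L02 cells (Homo sapiens) for cytotoxicity, read by MTT assay, with a stated time of 24 h; a lower number here means a stronger inhibitor, a higher number a weaker inhibitor. Compound 3 cannot be told apart from compound 1 or compound 2, since the three numbers lie within the usual scatter of one another.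

The next compound is compound 4 `COc1cc(/C=C2\CN(C)C/C(=C\c3ccc(C#N)cc3)C2=O)cc(OC)c1OC`. The change is 4-cyanophenyl in place of 2,4-dichlorophenyl on a double-bonded chain carbon bound to a double-bonded ring carbon, or in words, 4-cyanophenyl in place of 2,4-dichlorophenyl on a double-bonded chain carbon bound to a double-bonded ring carbon.

Among the compounds with values here, one measured step bears on this group: a 1.0-fold lower number from compound 2 to compound 3 (0.02 log units; within the scatter), within the scatter, for chloro in place of hydrogen on an aromatic carbon. The 4-cyanophenyl group also appears in compound 1, at 14000 nM. Within the data shown here, nothing measured so far moves beyond the scatter, so no real shift in either direction is expected in this assay. The estimated step is a 1.0-fold higher number from compound 3 to compound 4 (0.02 log units; within the scatter). For compound 4 the expected value is 14000 nM, with an estimated range of 8000 nM to 24000 nM.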

Compound 4, half-maximal inhibitory concentration: 18600 nM
For compound 4 the middle estimate is 1.3-fold (0.12 log units) below the measured one, within the range that was stated.
By their numbers in this assay, from the lowest: compounds 3, 1, 2 and 4 (each within the scatter of the next).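

In this assay, three single changes now lead to compound 4, and none can be told from the usual scatter. These are the exchange of the whole aromatic group at this place (a 1.4-fold higher number from compound 3 to compound 4 (0.14 log units; within the scatter)), cyano in place of chloro on an aromatic carbon (a 1.3-fold higher number from compound 2 to compound 4 (0.12 log units; within the scatter)), and an added methoxy group (a 1.3-fold higher number from compound 1 to compound 4 (0.12 log units; within the scatter)). The earlier compounds offered no direct comparison of 4-cyanophenyl with 2,4-dichlorophenyl on a double-bonded chain carbon bound to a double-bonded ring carbon, and no measurement at hand speaks to why these values stay so close.

On these data alone, whether an amine or a carboxylic acid on this aromatic ring would move the number beyond the scatter remains open. Also open, as far as these compounds go, is whether these changes would stay as flat in a different assay.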